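The compounds below may be only part of what the source reports. "The series", "measured", "known", "first", "only" and "open" are said of these compounds alone.

The three measured compounds:
Compound 1, `O=C(O)COc1ccc(Cl)cc1C#Cc1ccccc1Cl`, in an assay on CHO cells for displacement of a labelled ligand from prostaglandin D2 receptor 2 (Homo sapiens), read by scintillation counting (a lower number here means a stronger inhibitor, a higher number a weaker inhibitor), gives 28 nM.
Compound 2, `O=C(O)COc1ccc(Cl)cc1C#Cc1cncc(S(=O)(=O)N2CCOCC2)c1`, in this assay gives 41 nM.
Compound 3, `O=C(O)COc1ccc(Cl)cc1C#Cc1ccncc1`, in this assay gives 601 nM.

Compound 3 therefore stands highest of the three numbers in this assay. Its nearest neighbour is compound 2, whose value of 41 nM lies below it by more than the scatter, and compound 1 at 28 nM lies lower still. Among the measured compounds shown here, the only single-point step that reaches compound 3 is a 21-fold higher number from compound 1 to compound 3 (1.33 log units; beyond the scatter), a large loss on exchanging the 2-chlorophenyl for the pyridin-4-yl.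

Compound 4, `O=C(O)COc1ccc(Cl)cc1C#Cc1cccnc1`, keeps every atom of compound 3 and differs only in how they are joined: pyridin-3-yl in place of pyridin-4-yl on a triple-bonded carbon. For the measured compounds named here, no measured step isolates this particular exchange. What bears on it is that compound 2 also carries a pyridin-3-yl on the triple-bonded carbon, though with a further substituent, and gives 41 nM, far below compound 3. On that basis compound 4 is expected to move in this assay toward lower numbers than compound 3, by a step of about a 4.0-fold lower number from compound 3 to compound 4 (0.60 log units; beyond the scatter), well beyond the scatter. The estimate for compound 4 is 150 nM, with a range from 50 nM to 450 nM.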

Compound 4, inhibition constant: 117 nM
Estimate against measurement, compound 4: 1.3-fold (0.11 log units) above; the measured number falls inside the stated range.
By their numbers in this assay, from the lowest: compounds 1 and 2 (each within the scatter of the next); then compound 4; then compound 3.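

With the same atoms joined differently, pyridin-3-yl in place of pyridin-4-yl on a triple-bonded carbon gives a 5.1-fold lower number from compound 3 to compound 4 (0.71 log units; beyond the scatter) in this assay, so the number depends on how the pyridine ring is joined, and not only on a pyridine ring replacing the 2-chlorophenyl. The exchange recovers only part of the loss seen in a 21-fold higher number from compound 1 to compound 3 (1.33 log units; beyond the scatter), since pyridin-3-yl in place of 2-chlorophenyl still gives a 4.2-fold higher number from compound 1 to compound 4 (0.62 log units; beyond the scatter) at this position. Among the compounds shown here, the new compound also gives the first direct reading of the (morpholin-4-yl)sulfonyl, where hydrogen in its place gives a 2.9-fold higher number from compound 2 to compound 4 (0.46 log units; beyond the scatter), which shows that compound 2 owes its low number to the pyridin-3-yl and this substituent together, not to the pyridin-3-yl alone.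

No measurement here accounts for the size or direction of these steps. As far as these compounds go, it remains open how pyridin-2-yl would stand on the triple-bonded carbon, and whether a smaller group on the same aromatic carbon of the pyridin-3-yl, such as a methoxy, an amine or a simple sulfonamide, would match the (morpholin-4-yl)sulfonyl.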